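Piperidine amide to aryl urea on the shared core

The source may hold more compounds than are shown below. What is called first, only, known or untested is meant among the compounds shown, and "the series" means these compounds.

Compound 1 `CC(C)NC(=O)CN1CCN(c2ccc(OCC3CCN(C(=O)OC(C)C)CC3)cn2)CC1` and compound 2 `CCCS(=O)(=O)N1CCN(c2ccc(OCC3CCN(C(=O)CC(C)(C)C)CC3)cn2)CC1` share one core and were both run in a functional assay on CHO-K1 cells for agonist activity at Glucose-dependent insulinotropic receptor (Homo sapiens), read by a luciferase reporter, with a stated time of 5 h; a lower number here means that less compound is needed, a higher number that more compound is needed for the effect. Compound 1 reaches only a limit of the assay, > 10000 nM. For the measured compounds named here, compound 2 gives 2800 nM, the single measured number in the set. The other result belongs to compound 1 and is a limit (the limit of > 10000 nM in this assay, at which 1 of the 2 values shown sits). Compound 3 `CCCS(=O)(=O)N1CCN(c2ccc(OCC3CCN(C(=O)Nc4ccc(C(C)C)cc4)CC3)cn2)CC1` carries (4-isopropylphenyl)amino in place of neopentyl on a carbonyl carbon. Going by the values given here, no measured step covers such a change, so the direction rests on the structural difference alone; a modest gain beyond the scatter is expected. The step of a 2.3-fold lower number from compound 2 to compound 3 (0.37 log units; beyond the scatter) is the expected size. Compound 3 is estimated at 1200 nM, between 300 nM and 6000 nM.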

Compound 3, half-maximal effective concentration: 900 nM
Compound 3: middle estimate off by 1.3-fold (0.12 log units), on the high side; low and high end bracket the measured number.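

On a carbonyl carbon, this position tolerates an aromatic ring and a hydrogen-bond donor: in this assay, (4-isopropylphenyl)amino in place of neopentyl gives a 3.1-fold lower number from compound 2 to compound 3 (0.49 log units; beyond the scatter). The change brings in the ring and the donor together, so this step cannot separate their contributions. Nothing measured here explains the gain.

Still open, from the compounds shown here alone, is how phenylamino without the isopropyl group would read, and how tert-butyl or trifluoromethyl would compare in the isopropyl group's place. A benzylamino group on the same carbonyl carbon would test the effect of a longer link to the ring.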